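Second methoxy on the fused ring of compound 2

A few compounds are considered here, and "the series" means these few. Any claim that something is new, unique, unknown or untested is made for them only; others in the source may bear on it.

The measured compounds:
compound 1, `COc1ccc(-c2cc(=O)oc3ccccc23)cc1O`, 100 nM
compound 2, `COc1ccc(-c2cc(=O)oc3cccc(OC)c23)cc1O`, 190 nM

Both were tested in a functional assay on HCT-116 cells (Homo sapiens) for cytotoxicity, read by MTT assay, with a stated time of 48 h; on this read-out lower numbers stand for stronger inhibition and higher numbers for weaker inhibition. Within the data shown here, compound 2 has the highest of the two numbers so far; its nearest neighbour is compound 1, and the step of a 1.9-fold higher number from compound 1 to compound 2 (0.28 log units; within the scatter) stays within the scatter, so the two cannot be placed in order.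

Compound 3, `COc1cc(OC)c2c(-c3ccc(OC)c(O)c3)cc(=O)oc2c1`, is not yet measured. It differs from compound 2 by methoxy in place of hydrogen on an aromatic carbon. Among the measured compounds shown here, the only measured step that bears on this change is a 1.9-fold higher number from compound 1 to compound 2 (0.28 log units; within the scatter), which added the first methoxy to the same fused ring and brought no shift beyond the scatter. For the measured compounds named here, with one small step as the sole guide, a further methoxy on the same ring is expected to give a step of similar size, if any, in this assay for compound 3, most likely towards a somewhat higher number, as a 1.4-fold higher number from compound 2 to compound 3 (0.14 log units; within the scatter).

On that basis compound 3 is estimated at 260 nM, with a range from 100 nM to 650 nM.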

Compound 3, half-maximal inhibitory concentration: 210 nM
The estimate for compound 3 lay 1.2-fold (0.09 log units) above the measured number; the measured number falls inside the stated range.
By their numbers in this assay, from the lowest: compounds 1, 2 and 3 (each within the scatter of the next, the first and the last beyond it).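

In this assay, methoxy in place of hydrogen at this carbon, meta to the methoxy group already on the ring and para to a fused ring, gives a 1.1-fold higher number from compound 2 to compound 3 (0.04 log units; within the scatter). The earlier compounds shown here showed only a first methoxy on this ring; this result adds that a second one, at a different carbon of the same ring, also brings no shift that can be told from the scatter, so compound 2 and compound 3 cannot be placed in order. Nothing available on these compounds offers an explanation for this result.

The compounds shown carry only hydrogen or methoxy at this carbon, so it remains open whether a hydroxy group, an amine, a carboxylic acid or a longer chain there would move the number beyond the scatter. On these data alone, it also remains open whether this replacement would read the same way on cells other than the ones used here, since a single cell line gives no view of how general the result is.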